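The compounds below may be only part of what the source reports. "The series", "measured", "known", "first", "only" and "open" are said of these compounds alone.

Compound 1 `COc1ccc(-c2nc3cc(Cl)c(Cl)cc3[nH]2)cc1` gives 30000 nM in an ADME assay on Vero cells (Chlorocebus sabaeus) for cytotoxicity; a lower number here means that less compound is tolerated, a higher number that more compound is tolerated.
Compound 2 `Nc1ccc(-c2nc3cc(Cl)c(Cl)cc3[nH]2)cc1` gives in this assay only a limit, >= 100000 nM.
Compound 3 `O=C(CN1CCCC1)Nc1ccc(-c2nc3cc(Cl)c(Cl)cc3[nH]2)cc1` gives in this assay only a limit, > 100000 nM.

Compound 2 therefore stands at the upper edge of what this assay reports (the limit of >= 100000 nM in this assay, at which 1 of the 3 values shown sits). Compound 3 sits at a limit as well (the limit of > 100000 nM in this assay, at which 1 of the 3 values shown sits). Compound 4 `O=[N+]([O-])c1ccc(-c2nc3cc(Cl)c(Cl)cc3[nH]2)cc1` differs from compound 2 by nitro in place of amino on an aromatic carbon. Among the compounds with values here, two measured steps touch this position: an at least 3.3-fold higher number from compound 1 to compound 2 (0.52 log units; beyond the scatter), and a step that the two limits leave unreadable from compound 2 to compound 3. Neither involves a nitro group, and the direction of the new step cannot be read from them; from a limit, only a lower number could show up as a change. Compound 4 is estimated at 60000 nM, within 20000 nM to 100000 nM. That estimate means an expected at least 1.6-fold lower number from compound 2 to compound 4 (0.22 log units; that floor lies within the scatter).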

Compound 4, half-maximal cytotoxic concentration: >= 100000 nM
Compound 4 ended at the assay's limit; the forecaster's own chance of this, stated with the estimate: 40%; middle value at least 1.6-fold (0.22 log units) away from the limit.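

In this assay, compound 4 gives only a limit, >= 100000 nM. Changing methoxy to nitro gives an at least 3.3-fold higher number from compound 1 to compound 4 (0.52 log units; beyond the scatter), so a second group, very different from amino, also lifts the number clear of compound 1. The step between the amino of compound 2 and the nitro of compound 4 cannot be read, so the two groups cannot be ranked.

On these data alone, how far compound 2 and compound 4 lie past the limit stays open. So does whether a carboxylic acid or a longer alkyl chain at this position would give a number inside the assay's range.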